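The source may hold more compounds than are shown below. What is called first, only, known or untested is meant among the compounds shown, and "the series" means these compounds.

In a functional assay on B16-F10 cells (Mus musculus) for antiproliferative activity, read by MTT assay, with a stated time of 48 h (on this read-out lower numbers stand for stronger inhibition and higher numbers for weaker inhibition), compound 3 `COc1ccc(-c2csc(N3N=C(c4ccc(Br)cc4)CC3c3ccc4c(c3)OCCO4)n2)cc1` gives 1120 nM, the lowest of the three numbers recorded so far. Its nearest neighbour is compound 2 `Clc1ccc(C2=NN(c3nc(-c4ccc(Br)cc4)cs3)C(c3ccc4c(c3)OCCO4)C2)cc1`, which in this assay gives 2150 nM, a gap that lies within the scatter; the furthest is compound 1 `COc1ccc(C2=NN(c3nc(-c4ccc(Br)cc4)cs3)C(c3ccc4c(c3)OCCO4)C2)cc1`, which in this assay gives 2520 nM, a gap beyond the scatter. Compound 4 `Brc1ccc(C2=NN(c3nc(-c4ccc(Br)cc4)cs3)C(c3ccc4c(c3)OCCO4)C2)cc1` is obtained from compound 3 by one change: bromo in place of methoxy on an aromatic carbon. Among the measured compounds shown here, only one measured step resembles it, the exchange of methoxy for chloro on an aromatic carbon, which gave a 1.2-fold lower number from compound 1 to compound 2 (0.07 log units; within the scatter). That step stayed within the scatter, and no other halogen-for-methoxy exchange has been measured, so nothing beyond the scatter is expected here in either direction. Because a 1.2-fold lower number from compound 1 to compound 2 (0.07 log units; within the scatter) stayed within the scatter, the expected step is a 1.0-fold lower number from compound 3 to compound 4 (0.01 log units; within the scatter). Compound 4 is therefore estimated at 1100 nM in this assay, with a likely range from 500 nM to 2500 nM.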

Compound 4, half-maximal inhibitory concentration: 430 nM
Compound 4: middle estimate off by 2.6-fold (0.41 log units), on the high side; the measured number lies below the stated range.
By their numbers in this assay, from the lowest: compound 4; then compounds 3, 2 and 1 (each within the scatter of the next, the first and the last beyond it).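

In this assay the exchange of methoxy for bromo moves the number beyond the scatter at both 4-methoxyphenyl positions of the shared core (a 5.9-fold lower number from compound 1 to compound 4 (0.77 log units; beyond the scatter); a 2.6-fold lower number from compound 3 to compound 4 (0.42 log units; beyond the scatter)). The two halogens do not behave alike at the position where compound 1 carries its methoxy: chloro in its place stayed within the scatter (a 1.2-fold lower number from compound 1 to compound 2 (0.07 log units; within the scatter)), whereas bromo in place of chloro goes beyond it (a 5.0-fold lower number from compound 2 to compound 4 (0.70 log units; beyond the scatter)). Nothing available explains this difference between bromo and chloro.

As far as these compounds go, whether the gain is particular to bromo remains open, as iodo or trifluoromethyl at these positions could show. From the compounds shown here alone, it is also open whether chloro at the second position would match bromo there, or whether a single bromo, rather than the pair in compound 4, accounts for the step.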